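The compounds below may be only part of what the source reports. "The series", "measured", "known", "first", "only" and "open" are said of these compounds alone.

Three amides on one shared core have been run in a functional assay on A549 cells (Homo sapiens) for inhibition, read by MTT assay, with a stated time of 72 h; on this read-out higher numbers stand for weaker inhibition and lower numbers for stronger inhibition. Compound 1 `COc1ccccc1NC(=O)CCC(=O)OCCCCCCSc1ccc([N+](=O)[O-])c2nonc12` gives 1870 nM. Compound 2 `O=C(CCC(=O)OCCCCCCSc1ccc([N+](=O)[O-])c2nonc12)Nc1ccc(F)cc1` gives 6300 nM. Compound 3 `COc1ccc(NC(=O)CCC(=O)OCCCCCCSc2ccc([N+](=O)[O-])c3nonc23)cc1OC` gives 3890 nM, the second highest of the three numbers: it lies within the scatter of compound 2 and beyond the scatter against compound 1. All measured steps are swaps of one aryl group for another on the amide-type nitrogen: a 3.4-fold higher number from compound 1 to compound 2 (0.53 log units; beyond the scatter), a 2.1-fold higher number from compound 1 to compound 3 (0.32 log units; beyond the scatter) and a 1.6-fold lower number from compound 2 to compound 3 (0.21 log units; within the scatter). Compound 4 `O=C(CCC(=O)N1CCOCC1)OCCCCCCSc1ccc([N+](=O)[O-])c2nonc12` is not yet measured. Its change from compound 3 is morpholin-4-yl in place of (3,4-dimethoxyphenyl)amino on a carbonyl carbon. Going by the values given here, no measured step tests a replacement on this carbonyl carbon, nor the loss of the aryl group and of the hydrogen-bond donor, so there is no direct precedent; the three aryl variants together span only a modest range, which gives no ground to expect a large departure. Compound 4 is expected to give about 4500 nM, in the range 1500 nM to 15000 nM, kept wide for want of precedent. The expected step is a 1.2-fold higher number from compound 3 to compound 4 (0.06 log units; within the scatter), not clearly beyond the scatter in either direction.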

Compound 4, half-maximal inhibitory concentration: 1670 nM
Estimate against measurement, compound 4: 2.7-fold (0.43 log units) above, and the stated range covers the measured number.
By their numbers in this assay, from the lowest: compounds 4 and 1 (each within the scatter of the next); then compounds 3 and 2 (each within the scatter of the next).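

In this assay, the carbonyl carbon takes morpholin-4-yl in place of an arylamino group without any weakening: a 2.3-fold lower number from compound 3 to compound 4 (0.37 log units; beyond the scatter) and a 3.8-fold lower number from compound 2 to compound 4 (0.58 log units; beyond the scatter), while a 1.1-fold lower number from compound 1 to compound 4 (0.05 log units; within the scatter). The earlier compounds shown here varied only the aryl group, whereas compound 4 shows that neither an aromatic ring nor the amide hydrogen at this place is required for a number level with the best of the aryl amides, compound 1. No data on hand account for these steps.

Still open, from the compounds shown here alone, is whether piperidin-1-yl, with a ring carbon in place of the morpholine oxygen, or a free carboxylic acid on this carbonyl carbon would keep the number of compound 4. Going by these compounds, the shared core and linking chain stay fixed throughout, so the effect of a longer chain also remains untested in these compounds.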